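The source may hold more compounds than are shown below. What is called first, only, known or untested is meant among the compounds shown, and "the series" means these compounds.

Compounds measured so far:
compound 1, `CC(=O)N[C@@H]1CCC[C@H](C(=O)Nc2cc(-c3cnn4c3CC(C)(C)C4)c(Cl)cn2)C1`: 73 uL/min
compound 2, `CC(=O)N[C@@H]1CC[C@H](C(=O)Nc2cc(-c3cnn4c3CC(C)(C)C4)c(Cl)cn2)C1`: 97 uL/min

Both numbers come from an ADME assay on cells (Hepatocyte, Rattus norvegicus) for metabolic stability, using equilibrium dialysis; on this read-out lower numbers stand for slow clearance and higher numbers for fast clearance. Compound 2 has the higher of the two numbers, but the step of a 1.3-fold higher number from compound 1 to compound 2 (0.12 log units; within the scatter) lies within the scatter, so the two compounds cannot be told apart on this read-out.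

The next compound, compound 3, is `CC1(C)Cc2c(-c3cc(NC(=O)[C@H]4C[C@@H](O)C4)ncc3Cl)cnn2C1`. It differs from compound 2 in one place: 3-hydroxycyclobutyl in place of 3-acetamidocyclopentyl on a carbonyl carbon. The new group sits on the same carbonyl carbon, whose other neighbour is the amide-type nitrogen.

For the measured compounds named here, only one measured step exists, the one from compound 1 to compound 2, and it concerns the size of the ring carrying the acetamido group rather than the exchange of that whole group for a 3-hydroxycyclobutyl. It therefore gives little guidance here beyond showing that a change at this position left the number within the scatter. On that basis a step of no more than the scatter is expected, with the estimated step of a 1.2-fold lower number from compound 2 to compound 3 (0.08 log units; within the scatter), though with wide uncertainty. For compound 3 the expected value in this assay is 80 uL/min, within a range from 35 uL/min to 180 uL/min.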

Compound 3, intrinsic clearance in a liver preparation (reported as CLH), per the amount of preparation that the assay uses in the Hepatocyte assay: 157 uL/min
The estimate for compound 3 lay 2.0-fold (0.29 log units) below the measured number; low and high end bracket the measured number.
By their numbers in the Hepatocyte assay, from the lowest: compounds 1, 2 and 3 (each within the scatter of the next, the first and the last beyond it).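

For the compounds shown here, in the Hepatocyte assay, the exchange for 3-hydroxycyclobutyl on the carbonyl carbon gives the first step at this position that passes the scatter, a 2.2-fold higher number from compound 1 to compound 3 (0.33 log units; beyond the scatter), whereas the same group in place of 3-acetamidocyclopentyl stays inside it, a 1.6-fold higher number from compound 2 to compound 3 (0.21 log units; within the scatter). The number at this position can therefore move beyond the scatter, but the move is modest and is seen against only one of the two acetamido compounds. In a physicochemical assay for lipophilicity, using the shake flask method, measured as octanol-water partition, at pH 7.4 (a lower number here means a more polar compound, a higher number a more lipophilic compound), compound 2 gives 3.5 and compound 3 gives 3.2, and the step of a number 0.30 log units lower from compound 2 to compound 3 (within the scatter) shows that this exchange does not separate the two compounds on that read-out either.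

No measurement shown here bears on the cause of the step in the Hepatocyte assay. The exchange alters the ring and the group on it together, so the compounds shown leave open which of the two goes with the step, and how a 3-acetamidocyclobutyl or an amine such as 3-aminocyclobutyl on the same carbonyl carbon would read.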